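Methoxy for phenyl on the aryl ketone of compound 2

This account rests on a few compounds, and the source may have more. Where it says the series, first, only, none or still open, it means among the compounds named here.

Measured compounds:
compound 1 `CCOC(=O)c1ccc(Nc2ccnc(SCC(=O)c3ccc([N+](=O)[O-])cc3)n2)cc1` gives 27%
compound 2 `CC(=O)c1cccc(Nc2ccnc(SCC(=O)c3ccc(-c4ccccc4)cc3)n2)c1` gives 15%
compound 3 `CC(=O)c1ccc(Nc2ccnc(SCC(=O)c3ccc(Cl)cc3)n2)cc1` gives 10%

Three compounds of this series have been run in a functional assay on EKVX cells (Homo sapiens) for inhibition, read by sulforhodamine B assay, with a stated time of 48 h, tested at 10 uM; a lower number here means less inhibition of growth, a higher number more inhibition of growth at the concentration tested. Compound 2 stands second highest of the three numbers. Its nearest neighbour is compound 3, whose number is lower but within the scatter, so the two cannot be told apart. The furthest is compound 1, whose number lies higher by a margin beyond the scatter. All three sit in the lower part of the growth inhibition scale.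

Compound 4 `COc1ccc(C(=O)CSc2nccc(Nc3cccc(C(C)=O)c3)n2)cc1` has not yet been measured. It differs from compound 2 in one place: methoxy in place of phenyl on an aromatic carbon. Among the compounds with values here, no step between two measured compounds covers this exchange, so its size must be guessed from the spread of the three numbers, which is narrow. The change is expected to produce no step beyond the scatter, with a slight lean downward if anything, because compound 3 with its smaller substituent in the same region gives 10%. Compound 4 is estimated at 12%, between 0% and 28%. The expected step is a number 3 percentage points lower from compound 2 to compound 4 (within the scatter).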

Compound 4, percent growth inhibition at one concentration: 29%
Estimate against measurement, compound 4: 17 percentage points below; the measured number lies above the stated range.
By their numbers in this assay, from the lowest: compounds 3 and 2 (each within the scatter of the next); then compounds 1 and 4 (each within the scatter of the next).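

In this assay, within the data shown here, methoxy in place of phenyl on an aromatic carbon, para to a large group, gives a number 14 percentage points higher from compound 2 to compound 4 (beyond the scatter), the first step that can be read between two compounds differing in one place. It shows that the number responds to what this position carries, although the step is modest: the group with 2 heavy atoms and 1 hydrogen-bond acceptor goes with more inhibition of growth than the one with 6 heavy atoms, one aromatic ring and no acceptor. Nothing measured here says why the number moves with this exchange.

On these data alone, a single exchange cannot separate the loss of the aromatic ring from the arrival of the oxygen, so it remains open how a plain hydrogen, an ethoxy group or a hydroxyl group at the same place would compare. As far as these compounds go, it is also open whether methoxy in place of phenyl gives a similar step when the rest of the molecule is as in compound 1 or compound 3.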